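From nitro to formyl: an estimate for compound 4

This account rests on a few compounds, and the source may have more. Where it says the series, first, only, none or still open, it means among the compounds named here.

Measured in a functional assay on SK-OV-3 cells (Homo sapiens) for inhibition, read by CCK-8 assay, with a stated time of 70 h; on this read-out lower numbers stand for stronger inhibition and higher numbers for weaker inhibition
Compound 1 `COc1ccc(OCCOCCNC2CCCC2)cc1` gives 99100 nM
Compound 2 `O=C(O)c1ccccc1COc1ccc(OCCOCCNC2CCCC2)cc1` gives > 100000 nM, a limit of the assay
Compound 3 `O=[N+]([O-])c1ccc(COc2ccc(OCCOCCNC3CCCC3)cc2)cc1` gives 20300 nM

Compound 3 carries the lowest number of the three. Compound 4 `O=Cc1ccc(COc2ccc(OCCOCCNC3CCCC3)cc2)cc1` differs from it in one place: formyl in place of nitro on an aromatic carbon. The formyl group of compound 4 sits para to a large group. Within the data shown here, two measured steps bear on this group: a 4.9-fold lower number from compound 1 to compound 3 (0.69 log units; beyond the scatter) and an at least 4.9-fold lower number from compound 2 to compound 3 (0.69 log units; beyond the scatter). Neither separates the nitro from the ring that carries it, and that ring stays. With a 4.9-fold lower number from compound 1 to compound 3 (0.69 log units; beyond the scatter) as the only exact size, no step beyond the scatter is expected in this assay. The expected change is a 1.2-fold higher number from compound 3 to compound 4 (0.09 log units; within the scatter). For compound 4 the estimate is 25000 nM, with an expected range from 9000 nM to 70000 nM.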

Compound 4, half-maximal inhibitory concentration: 45000 nM
Beside the measured number, compound 4's estimate is 1.8-fold (0.26 log units) below it; low and high end bracket the measured number.
By their numbers in this assay, from the lowest: compound 3; then compound 4; then compound 1. At a limit, above all of these: compound 2.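

In this assay, the group on this aromatic carbon proves to count by itself: with the ring kept, formyl in place of nitro gives a 2.2-fold higher number from compound 3 to compound 4 (0.35 log units; beyond the scatter). The 4-formylphenyl group still gives a 2.2-fold lower number from compound 1 to compound 4 (0.34 log units; beyond the scatter), so the nitro is not needed for a step beyond the scatter from compound 1. Compound 2 is a limit, and the comparison with it, an at least 2.2-fold lower number from compound 2 to compound 4 (0.34 log units; beyond the scatter), gives only a bound: the limit of > 100000 nM in this assay, at which 1 of the 4 values shown sits.

The compounds shown leave open how an amine or a nitrile on this same aromatic carbon would compare. They also leave open whether a formyl group elsewhere on the ring would give the same number.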